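Amide variation on a diaryl aminothiophene core

This account rests on a few compounds, and the source may have more. Where it says the series, first, only, none or still open, it means among the compounds named here.

Measured so far in a functional assay on A549 cells (Homo sapiens) for inhibition, read by sulforhodamine B assay, with a stated time of 72 h; on this read-out higher numbers stand for weaker inhibition and lower numbers for stronger inhibition:
Compound 1 `Nc1sc(-c2ccc(Cl)cc2)c(-c2ccc(Cl)cc2)c1C(=O)N1CCCC1` gives 890 nM.
Compound 2 `Nc1sc(-c2ccc(Cl)cc2)c(-c2ccc(Cl)cc2)c1C(=O)N1CCNCC1` gives 1020 nM.
Compound 3 `Nc1sc(-c2ccc(Cl)cc2)c(-c2ccc(Cl)cc2)c1C(=O)NC1CC1` gives 1950 nM.

Compound 3 has the highest number of the three. One of its gaps is a 1.9-fold higher number from compound 2 to compound 3 (0.28 log units; within the scatter), within the scatter, while the other is a 2.2-fold higher number from compound 1 to compound 3 (0.34 log units; beyond the scatter), a modest step beyond the scatter. Between compound 1 and compound 2 the step is a 1.1-fold higher number from compound 1 to compound 2 (0.06 log units; within the scatter), so the two cyclic tertiary amides sit together and only the cyclopropylamino secondary amide stands apart.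

Compound 4 `Nc1sc(-c2ccc(Cl)cc2)c(-c2ccc(Cl)cc2)c1C(=O)N1CCCCC1=O` carries the next change on the carbonyl carbon: 2-oxopiperidin-1-yl in place of cyclopropylamino on a carbonyl carbon. The entering group is again a ring closed onto the amide nitrogen, as in compound 1 and compound 2, which is the pattern that gave the lower numbers. The steps from compound 1 and from compound 2 to compound 3 are therefore the ones that bear on this change; they suggest a return toward the numbers of compound 1 and compound 2, so a modest downward step is expected, a 1.8-fold lower number from compound 3 to compound 4 (0.25 log units; within the scatter), with the added ring oxygen an unknown. For compound 4 the estimate in this assay is 1100 nM, in the range 450 nM to 2800 nM.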

Compound 4, half-maximal inhibitory concentration: 1820 nM
The estimate for compound 4 lay 1.7-fold (0.22 log units) below the measured number; measured number inside the range.
By their numbers in this assay, from the lowest: compounds 1, 2, 4 and 3 (each within the scatter of the next, the first and the last beyond it).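

In this assay, the step to 2-oxopiperidin-1-yl on the carbonyl carbon is a 1.1-fold lower number from compound 3 to compound 4 (0.03 log units; within the scatter), so exchanging cyclopropylamino for a ring closed onto the amide nitrogen, with loss of the amide hydrogen, gives no change that can be read at this position. Within the data shown here, the other two steps are a 1.8-fold higher number from compound 2 to compound 4 (0.25 log units; within the scatter) and a 2.0-fold higher number from compound 1 to compound 4 (0.31 log units; beyond the scatter), the last a modest one, so the ring-closed amides no longer sit together as the earlier compounds suggested, and ring closure alone does not place a compound with the pyrrolidin-1-yl amide. No measurement is available that would explain these steps.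

The 2-oxopiperidin-1-yl group differs from the pyrrolidin-1-yl group in both ring size and ring carbonyl, so the compounds shown leave open which of the two matters; the plain piperidin-1-yl amide would separate them. Also open, on these data alone, is whether an open-chain tertiary amide such as diethylamino, or a piperazin-1-yl ring carrying a methyl group or a carboxylic acid chain, would stay within this narrow range of numbers.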